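The compounds below may be only part of what the source reports. "The series", "measured", "known", "first", "only" and "open" are said of these compounds alone.

Compound 1 `NC1=NC2(CCOCC2)N(OCCCOc2cc(Cl)c(Cl)cc2Cl)C(N)=N1` has no result in a functional assay on HepG2 cells (Homo sapiens) for antiproliferative activity, read by MTT assay, with a stated time of 72 h; on this read-out lower numbers stand for stronger inhibition and higher numbers for weaker inhibition; the record for compound 1 reads "not determined" (no result reported). Among the measured compounds shown here, the only number comes from compound 2 `NC1=NC2(CCSCC2)N(OCCCOc2ccc(Br)cc2)C(N)=N1`, which in this assay gives 1400 nM. Compound 3 `Cc1cc(C)cc(OCCCON2C(N)=NC(N)=NC23CCOCC3)c1` differs from compound 1 by 3,5-dimethylphenyl in place of 2,4,5-trichlorophenyl on an oxygen on a saturated carbon. Without a measured step for that change, nothing shows its direction, and the expectation for compound 3 in this assay is a change no larger than the usual scatter, in either direction. Compound 3 is therefore estimated at 3000 nM, expected to fall between 800 nM and 12000 nM.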

Compound 3, half-maximal inhibitory concentration: 680 nM
For compound 3 the middle estimate is 4.4-fold (0.64 log units) above the measured one; the measured number lies below the stated range.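

Among the compounds shown here, the value for compound 3 in this assay gives no new step, as it cannot be paired with a number for compound 1 or compared with compound 2. The compounds shown leave open how replacing 2,4,5-trichlorophenyl with 3,5-dimethylphenyl alone shifts potency. No measured evidence bears on this result.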